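From a 4-nitrobenzyl to a 3-(trifluoromethyl)benzyl group

This account rests on a few compounds, and the source may have more. Where it says the series, first, only, none or still open, it means among the compounds named here.

- compound 1 `Cc1cc(Nc2ccc(C(=O)/C=C/c3ccc4ccccc4c3)cc2)n2nc(SCc3ccc(Cl)cc3)nc2n1`: 570 nM
- compound 2 `Cc1cc(Nc2ccc(C(=O)/C=C/c3ccc4ccccc4c3)cc2)n2nc(SCc3ccc([N+](=O)[O-])cc3)nc2n1`: 1130 nM
- compound 3 `Cc1cc(Nc2ccc(C(=O)/C=C/c3ccc4ccccc4c3)cc2)n2nc(SCc3cccc([N+](=O)[O-])c3)nc2n1`: 790 nM

All three compounds were tested in a functional assay on SW-620 cells (Homo sapiens) for cytotoxicity, read by MTT assay, with stated times of 4 h and 72 h, tested at 5 uM; a lower number here means a stronger inhibitor, a higher number a weaker inhibitor. Compound 2 gives 1130 nM and stands level with the other two: the measured steps are a 1.4-fold lower number from compound 2 to compound 3 (0.16 log units; within the scatter) and a 2.0-fold higher number from compound 1 to compound 2 (0.30 log units; within the scatter).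

In compound 4 `Cc1cc(Nc2ccc(C(=O)/C=C/c3ccc4ccccc4c3)cc2)n2nc(SCc3cccc(C(F)(F)F)c3)nc2n1`, the shared core stays, and a 3-(trifluoromethyl)phenyl replaces the 4-nitrophenyl on a saturated chain carbon bound to a sulfur: 3-(trifluoromethyl)phenyl in place of 4-nitrophenyl on a saturated chain carbon bound to a sulfur. Among the measured compounds shown here, no measured compound carries a trifluoromethyl group, so the evidence is indirect.

For the measured compounds named here, the measured steps at this place are the only guide. Changing 4-nitrophenyl to 3-nitrophenyl gave a 1.4-fold lower number from compound 2 to compound 3 (0.16 log units; within the scatter). Changing 4-chlorophenyl to 3-nitrophenyl gave a 1.4-fold higher number from compound 1 to compound 3 (0.14 log units; within the scatter), and nitro in place of chloro gave a 2.0-fold higher number from compound 1 to compound 2 (0.30 log units; within the scatter). Each of these three changes left this assay within the scatter, so the three compounds offer no sign of a large response to changes at this place. No step beyond the scatter is therefore expected for the new group, and the expected change is a 1.5-fold lower number from compound 2 to compound 4 (0.18 log units; within the scatter). For compound 4 the estimated value is 750 nM, with an expected range of 320 nM to 1700 nM.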

Compound 4, half-maximal inhibitory concentration: 2070 nM
The estimate for compound 4 lay 2.8-fold (0.44 log units) below the measured number; the measured number lies above the stated range.
By their numbers in this assay, from the lowest: compounds 1, 3, 2 and 4 (each within the scatter of the next, the first and the last beyond it).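

In this assay, changes on the saturated chain carbon bound to the sulfur now produce steps beyond the scatter, which none of the first three compounds did: trifluoromethyl in place of nitro gives a 2.6-fold higher number from compound 3 to compound 4 (0.42 log units; beyond the scatter), and 3-(trifluoromethyl)phenyl in place of 4-chlorophenyl gives a 3.6-fold higher number from compound 1 to compound 4 (0.56 log units; beyond the scatter). Among the compounds shown here, this place is therefore not as flat as the earlier compounds suggested, although the response remains modest and the step that prompted the estimate, a 1.8-fold higher number from compound 2 to compound 4 (0.26 log units; within the scatter), stays within the scatter. Nothing shown here gives a measured reason for these steps.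

With only compound 3 and compound 4 sharing a 3-substituted benzyl group and differing in the substituent, one pair carries the clearest reading, and the compounds shown cannot tell whether the trifluoromethyl group itself or its combination with that ring place sets the number. Nor do they show how this assay would respond to a methoxy group or an amine on the ring, or to a longer chain in place of the benzyl group on the sulfur.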